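The source may hold more compounds than are shown below. What is called first, only, known or untested is meant among the compounds shown, and "the series" means these compounds.

Measured in a functional assay on U-937 cells (Homo sapiens) for antiproliferative activity, read by CCK-8 assay, with a stated time of 24 h; a lower number here means a stronger inhibitor, a higher number a weaker inhibitor:
- Compound 1, `CN(C)Cc1ccc(NC(=O)NN=C(c2ccccc2)c2ccccc2)cc1`: > 25000 nM (a limit)
- Compound 2, `CCN(CC)Cc1ccc(NC(=O)NN=C(c2ccccc2)c2ccccc2)cc1`: > 25000 nM (a limit)

Compound 2 therefore has no numerical value, only the limit > 25000 nM. The same holds across the measured set: the limit of > 25000 nM in this assay, at which 2 of the 2 values shown sit.

The next analogue is compound 3, `CC1CCN(Cc2ccc(NC(=O)NN=C(c3ccccc3)c3ccccc3)cc2)CC1`. Its change is 4-methylpiperidin-1-yl in place of diethylamino on a saturated chain carbon bound to an aromatic carbon, so the open diethylamino group gives way to a six-membered non-aromatic ring.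

Going by the values given here, only one measured step bears on this change. That step, a step that the two limits leave unreadable from compound 1 to compound 2, also exchanges the amino group at this place, but it has no readable size. It offers no size or direction to carry over, so no clear shift is expected in this assay, and another limit is the likeliest report. The expected a number no higher from compound 2 to compound 3 (the limit leaves the size open) is correspondingly a cautious estimate, with no direction firmly indicated. The estimate for compound 3 is 25000 nM, with an expected range of 10000 nM to 50000 nM.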

Compound 3, half-maximal inhibitory concentration: > 25000 nM
Compound 3: a limit, no number (the forecaster's own chance of this, stated with the estimate: 65%); the middle value sits exactly at the limit.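

Compound 3 also returns only a limit in this assay, so the steps reaching it from compound 1 and compound 2 cannot be read in size or direction. All three compounds share one limit: the limit of > 25000 nM in this assay, at which 3 of the 3 values shown sit. The compounds shown leave open how these amino groups would rank, since none of them gives a numerical value.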